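The source may hold more compounds than are shown below. What is called first, only, known or untested is meant among the compounds shown, and "the series" means these compounds.

Compound 3 `CCCCc1nc(C)c(CC(=O)OC(C)C)c(=O)n1Cc1ccc(-c2ccccc2-c2noc(=O)[nH]2)cc1` was tested in an ADME assay on microsomes from liver (Homo sapiens) for metabolic stability, with a stated time of 30 min (on this read-out higher numbers stand for a more stable compound and lower numbers for a less stable compound), and gives 17.5%. Its closest neighbour among the measured compounds is compound 1 `CCCCc1nc(C(C)C)c(CC(=O)OC2CCCCC2)c(=O)n1Cc1ccc(-c2ccccc2-c2noc(=O)[nH]2)cc1`, which gives 13.3%; the two values lie within the usual scatter of each other. Compound 2 `CCCCc1nc(C)c(CC(=O)OCC)c(=O)n1Cc1ccc(-c2ccccc2-c2noc(=O)[nH]2)cc1` gives 46.6%; 46.5% (2 entries), and its repeat entries the several entries of compound 2 in this assay, 46.6%; 46.5% (2 entries) agree closely.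

Compound 4 `CCCCc1nc(C)c(CC(=O)OC2CC2)c(=O)n1Cc1ccc(-c2ccccc2-c2noc(=O)[nH]2)cc1` differs from compound 3 by one change: cyclopropyl in place of isopropyl on an oxygen next to a carbonyl group. Within the data shown here, no measured pair shows this change, so its effect is unknown. The expected step of a number 2.5 percentage points higher from compound 3 to compound 4 (within the scatter) is small, in no sure direction, and likely within the scatter. For compound 4 the estimate is 20%, with a range from 8% to 40%.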

Compound 4, percent of the compound remaining: 34.5%
For compound 4 the middle estimate is 14.5 percentage points below the measured one, within the range that was stated.
By their numbers in this assay, from the lowest: compounds 1 and 3 (each within the scatter of the next); then compound 4.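

In this assay, cyclopropyl in place of isopropyl on an oxygen next to a carbonyl group gives a number 17 percentage points higher from compound 3 to compound 4 (beyond the scatter). Both groups hold 3 carbon atoms, so at this position the number can move well beyond the scatter with no change in the count of heavy atoms, only with the closing of a three-membered ring. From the compounds shown here alone, whether a cyclobutyl group or a longer chain on this oxygen would give a higher or a lower number stays open. Nothing measured here explains the size of this step.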